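A few compounds are considered here, and "the series" means these few. Any claim that something is new, unique, unknown or untested is made for them only; others in the source may bear on it.

Compound 1, `C[C@@H](O)[C@H](NC(=O)CN(c1nc(Cl)nc2[nH]cnc12)C1CC1)C(=O)O`: 30.1%
Compound 2, `O=C(CN(c1nc(Cl)nc2[nH]cnc12)C1CC1)N[C@@H](CO)C(=O)O`: 39.8%

Among the compounds with values here, in a functional assay on the whole organism (Tail, strain ICR) with Mus musculus as the target, in the tail flick test, with a stated time of 60 min, at a dose of 25 umol/kg by the oral route (a higher number here means a stronger effect of the compound at the dose given, a lower number a weaker effect), compound 2 holds the higher of these two numbers, the only other one being compound 1 at a number 9.7 percentage points higher from compound 1 to compound 2 (within the scatter), a step that stays within the scatter. Compound 3, `N=C(N)NCCC[C@H](NC(=O)CN(c1nc(Cl)nc2[nH]cnc12)C1CC1)C(=O)O`, differs from compound 2 by a group of 6 heavy atoms (3 carbon, 3 nitrogen; no ring) in place of one oxygen atom, on a saturated chain carbon, two bonds along the chain from an amide-type nitrogen and a carbonyl carbon. Within the data shown here, no measured step touches this part of the molecule; the one measured step replaced a methyl with hydrogen elsewhere and stayed within the scatter. Compound 3 is therefore expected to sit near compound 2, at 36% (range 10% to 65%), an expected step of a number 3.8 percentage points lower from compound 2 to compound 3 (within the scatter), with wide uncertainty.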

Compound 3, a percentage reported as activity, at one dose (the size of the read-out at that dose, not a potency): 51%
Beside the measured number, compound 3's estimate is 15 percentage points below it; the range from low to high includes it.
By their numbers in this assay, from the lowest: compounds 1 and 2 (each within the scatter of the next); then compound 3.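

In this assay, within the data shown here, this position on the saturated chain carbon is the first to give a change beyond the scatter: the group of 6 heavy atoms (3 carbon, 3 nitrogen; no ring) in place of the hydroxy oxygen gives a number 11.2 percentage points higher from compound 2 to compound 3 (beyond the scatter). The larger replacement of the side chain gives a number 20.9 percentage points higher from compound 1 to compound 3 (beyond the scatter), so compound 3 stands clear of both earlier compounds. Nothing available explains this gain. The compounds shown leave open whether a simple amine at the chain end would do as well as this group. They also leave open whether a longer chain or a carboxylic acid there would carry the number higher or lower.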